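The compounds below may be only part of what the source reports. "The series", "measured", "known", "first", "only" and "open" are said of these compounds alone.

Of the compounds shown here, three have so far been tested in an ADME assay on Huh-7 cells (Homo sapiens) for cytotoxicity; on this read-out lower numbers stand for higher toxicity in this test and higher numbers for lower toxicity in this test. Compound 1, `Cc1ccccc1CNc1nn(-c2ccc(F)cc2F)cc1CNCCN1CCN(C)CC1`, gives > 20000 nM in this assay, which is a limit of the assay rather than a number. Compound 3, `Cc1ccccc1-c1nn(-c2cc(F)ccc2F)cc1CNCCN1CCN(C)CC1`, likewise gives > 20000 nM in this assay, again a limit and not a number. For the measured compounds named here, compound 2, `CN1CCN(CCNCc2cn(-c3ccc([N+](=O)[O-])cc3)nc2-c2ccc(C(F)(F)F)cc2)CC1`, is the one compound that returns a number: in this assay compound 2 gives 3200 nM. Compound 1 therefore stands at the top of what the assay reports, alongside compound 3, since (the limit of > 20000 nM in this assay, at which 2 of the 3 values shown sit), while compound 2 sits lower.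

Compound 4, `CN1CCN(CCNCc2cn(-c3ccc(F)cc3F)nc2C2CCCCC2)CC1`, has not yet been measured. It differs from compound 1 in a single place: cyclohexyl in place of (2-methylbenzyl)amino on an aromatic carbon. Going by the values given here, no pair of measured compounds differs in this way, so there is no measured step to lean on; the expectation rests on compound 1 alone, which in this assay gives > 20000 nM, a limit. With the core and the 2,4-difluorophenyl group unchanged, the step from compound 1 to compound 4 is expected to be a step that the limit leaves unreadable from compound 1 to compound 4, that is, none beyond the usual scatter. Compound 4 is therefore estimated at about 25000 nM in this assay, with a range from 10000 nM to 60000 nM.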

Compound 4, half-maximal cytotoxic concentration: > 20000 nM
Compound 4 ended at the assay's limit (the forecaster's own chance of this, stated with the estimate: 60%); the middle value is on the limit's open side.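

Compound 1 and compound 4 both stand at a limit of this assay rather than at a number, so no step between them can be read: the limit of > 20000 nM in this assay, at which 3 of the 4 values shown sit.

The compounds shown leave open what numbers compound 1 and compound 4 would give, and so whether cyclohexyl in place of (2-methylbenzyl)amino changes this read-out at all.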